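Chain Lengthening on a Pyrrolidine Amide

A few compounds are considered here, and "the series" means these few. Any claim that something is new, unique, unknown or untested is made for them only; others in the source may bear on it.

Compound 2 `CCCCCCCCCCCCCCCC(=O)N1CCCC1` gives 4.6 ug/mL in a functional assay on NCI/ADR-RES cells (Homo sapiens) for antiproliferative activity, read by sulforhodamine B assay, with a stated time of 48 h (on this read-out higher numbers stand for weaker inhibition of growth and lower numbers for stronger inhibition of growth), the lowest of the three numbers measured. Compound 3 `CCCCCCCCCCCCCCCC(=O)N1CCOCC1` gives 6.2 ug/mL in this assay, and the step of a 1.3-fold higher number from compound 2 to compound 3 (0.13 log units; within the scatter) lies within the scatter. Compound 1 `CCCCCCCCCCCCCCCCCC(=O)N1CCOCC1` gives 33.1 ug/mL in this assay. Compound 4 `CCCCCCCCCCCCCCCCCC(=O)N1CCCC1` has not been measured; it differs from compound 2 by ethyl in place of hydrogen on a saturated chain carbon, ten or more bonds along the chain from a carbonyl carbon. Among the compounds with values here, one measured step bears on this change, a 5.3-fold lower number from compound 1 to compound 3 (0.73 log units; beyond the scatter), which is the same exchange run in the opposite direction among compounds bearing morpholin-4-yl on the carbonyl carbon. Reversing it, a higher number of comparable size is expected for compound 4 in this assay. Compound 4 is therefore estimated at 20 ug/mL, within a range from 8 ug/mL to 50 ug/mL. That estimate means an expected step of a 4.3-fold higher number from compound 2 to compound 4 (0.64 log units; beyond the scatter).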

Compound 4, concentration for 50% growth inhibition: 7.1 ug/mL
For compound 4 the middle estimate is 2.8-fold (0.45 log units) above the measured one; measured number below the stated range.
By their numbers in this assay, from the lowest: compounds 2, 3 and 4 (each within the scatter of the next); then compound 1.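

On the pyrrolidin-1-yl amides, ethyl in place of hydrogen on the saturated chain carbon gives a 1.5-fold higher number from compound 2 to compound 4 (0.19 log units; within the scatter) in this assay, so the chain change does not carry the same size on both cores: the same change on two cores in this assay, a 5.3-fold lower number (0.73 log units; beyond the scatter) from compound 1 to compound 3 and a 1.5-fold lower number (0.19 log units; within the scatter) from compound 4 to compound 2, 3.5-fold (0.54 log units) apart, beyond the scatter of two such steps. In the other direction, pyrrolidin-1-yl in place of morpholin-4-yl on the carbonyl carbon gives a 4.7-fold lower number from compound 1 to compound 4 (0.67 log units; beyond the scatter), so this exchange, within the scatter on the other chain, depends on the chain: the same change on two cores in this assay, a 1.3-fold higher number (0.13 log units; within the scatter) from compound 2 to compound 3 and a 4.7-fold higher number (0.67 log units; beyond the scatter) from compound 4 to compound 1, 3.5-fold (0.54 log units) apart, beyond the scatter of two such steps. The compounds shown leave open whether this dependence holds for a longer chain, or for piperidin-1-yl on the carbonyl carbon.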